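Trimethoxyphenyl pyrazole chalcones: adding a methoxy to the ketone ring

A few compounds are considered here, and "the series" means these few. Any claim that something is new, unique, unknown or untested is made for them only; others in the source may bear on it.

Compound 2 `COc1ccc(C(=O)/C=C/c2cc(-c3cc(OC)c(OC)c(OC)c3)n[nH]2)cc1OC` gives -96% in a functional assay on A498 cells (Homo sapiens) for cytotoxicity, read by sulforhodamine B assay, with a stated time of 48 h, tested at 100 uM (a lower number here means a stronger effect, a higher number a weaker effect of the compound at the concentration tested), level with compound 1 `COc1cc(-c2cc(/C=C/C(=O)c3ccc(N)cc3)[nH]n2)cc(OC)c1OC` at -96% and together the lowest of the three numbers; compound 3 `COc1ccc(C(=O)/C=C/c2cc(-c3cc(OC)c(OC)c(OC)c3)n[nH]2)cc1` gives -34%. The steps shown are no change at the digits printed from compound 1 to compound 2 (within the scatter), a number 62 percentage points higher from compound 1 to compound 3 (beyond the scatter) and a number 62 percentage points higher from compound 2 to compound 3 (beyond the scatter). Compound 4 `COc1cc(C(=O)/C=C/c2cc(-c3cc(OC)c(OC)c(OC)c3)n[nH]2)cc(OC)c1OC` differs from compound 2 by methoxy in place of hydrogen on an aromatic carbon. Among the measured compounds shown here, the step of a number 62 percentage points higher from compound 2 to compound 3 (beyond the scatter) bears most directly, since it concerns a methoxy on the same ring, yet it runs the other way; a further methoxy on a ring already carrying two has no measured counterpart here. The step of a number 4 percentage points higher from compound 2 to compound 4 (within the scatter) is therefore expected to stay within the scatter. Compound 4 is estimated at -92%, between -100% and -65%.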

Compound 4, a percentage reported as activity, at one concentration (the size of the read-out at that concentration, not a potency): -98%
Beside the measured number, compound 4's estimate is 6 percentage points above it, and the stated range covers the measured number.
By their numbers in this assay, from the lowest: compounds 4, 1 and 2 (each within the scatter of the next); then compound 3.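

In this assay, the step of a number 2 percentage points lower from compound 2 to compound 4 (within the scatter) shows that a methoxy can take this place on the ring, ortho to a methoxy group, without a shift beyond the scatter. Among the compounds shown here, the large step of a number 62 percentage points higher from compound 2 to compound 3 (beyond the scatter), also on this ring, therefore has no counterpart when this methoxy is added. Nothing available explains this flat step. Going by these compounds, whether an ethoxy, a hydroxy or a chlorine at this place would hold the number remains open. At this single concentration, compounds 1, 2 and 4 also remain unseparated in the size of their effect.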